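This account rests on a few compounds, and the source may have more. Where it says the series, first, only, none or still open, it means among the compounds named here.

Measured compounds:
Compound 1, `COc1cc(-c2nn(-c3cccc(NC(=O)Nc4ccc(Cl)c(Cl)c4)c3)cc2-c2ccncc2)ccc1Cl`, 1720 nM.
Compound 2, `O=C(Nc1cccc(-n2cc(-c3ccncc3)c(-c3ccc(Cl)c(O)c3)n2)c1)Nc1ccc(Cl)c(Cl)c1`, 9490 nM.
Compound 3, `COc1cc(-c2nn(-c3cccc(NC(=O)c4ccccc4)c3)cc2-c2ccncc2)ccc1Cl`, 3230 nM.

These three were measured in a functional assay on COLO 205 cells (Homo sapiens) for inhibition, read by sulforhodamine B assay, with a stated time of 48 h; a higher number here means a weaker inhibitor of growth, a lower number a stronger inhibitor of growth. Compound 2 gives the highest number of the three: compound 1 reaches 1720 nM, and the step is a 5.5-fold higher number from compound 1 to compound 2 (0.74 log units; beyond the scatter), while compound 3 reaches 3230 nM, a number that sits between the other two. Going from compound 1 to compound 3 the change is a 1.9-fold higher number from compound 1 to compound 3 (0.27 log units; within the scatter).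

Compound 4, `O=C(Nc1cccc(-n2cc(-c3ccncc3)c(-c3ccc(Cl)c(O)c3)n2)c1)Nc1ccc(Cl)c(C(F)(F)F)c1`, is the next compound to be measured in this assay. It differs from compound 2 in one place: trifluoromethyl in place of chloro on an aromatic carbon. Neither of the measured steps touches this part of the molecule; one swaps methyl for hydrogen on an oxygen, the other replaces the whole (3,4-dichlorophenyl)amino group on the carbonyl carbon. Among the measured compounds shown here, no measured step therefore bears directly on the change from compound 2 to compound 4, and no step beyond the scatter is expected in this assay. The expected outcome for compound 4 is 8000 nM, with a range from 3000 nM to 25000 nM. The step this estimate implies is a 1.2-fold lower number from compound 2 to compound 4 (0.07 log units; within the scatter), expected to remain within the scatter.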

Compound 4, concentration for total growth inhibition: 6750 nM
For compound 4 the middle estimate is 1.2-fold (0.07 log units) above the measured one; the measured number falls inside the stated range.
By their numbers in this assay, from the lowest: compounds 1 and 3 (each within the scatter of the next); then compounds 4 and 2 (each within the scatter of the next).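

In this assay, among the compounds shown here, the step to trifluoromethyl gives a 1.4-fold lower number from compound 2 to compound 4 (0.15 log units; within the scatter) and is the first measured change made on the 3,4-dichlorophenyl ring itself, rather than to the oxygen on the other aryl ring or to the whole (3,4-dichlorophenyl)amino group. At this place, ortho to a chloro group, a chloro group of one heavy atom can give way to a trifluoromethyl group of four heavy atoms with no step beyond the scatter, at least in the compound 2 setting. Nothing measured here gives a reason for this result.

The compounds shown leave open whether the same swap behaves alike when the oxygen carries a methyl group, as in compound 1. They also leave open how a nitrile, an amine or a carboxylic acid would fare at this place.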